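The source may report more compounds than this note shows. Statements on the series, on what has been measured and on what is new or still open speak of the compounds shown alone.

Compound 1, `Cc1[nH]c2ccc(Cl)cc2c1SC1CCNCC1`, was tested in a functional assay on the whole organism with Mus musculus as the target, in the hot plate test (a higher number here means that more compound is needed for the effect, a lower number that less compound is needed), where compound 1 gives 9.9 mg/kg. Compound 2, `Cc1[nH]c2ccc(Br)cc2c1SC1CCNCC1`, carries one change relative to compound 1, (bromo in place of chloro on an aromatic carbon), and in this assay compound 2 gives 3.1 mg/kg. The step this change made is a 3.2-fold lower number from compound 1 to compound 2 (0.50 log units; beyond the scatter). Compound 3, `CN1CCC(Sc2cn(C)c3ccc(Cl)cc23)CC1`, has a core that differs from the core of compound 1, but the difference between the two cores is not broken down here; in this assay compound 3 gives 9.3 mg/kg, which sits within the usual scatter of the value of compound 1. Compound 4, `CN1CCC(Sc2cn(C)c3ccc(Br)cc23)CC1`, has not yet been measured. It stands to compound 3 as compound 2 stands to compound 1, through (bromo in place of chloro on an aromatic carbon), the same change at the same place. The author expects the step from compound 3 to compound 4 to be a 2.8-fold lower number from compound 3 to compound 4 (0.45 log units; beyond the scatter), resting on the earlier step of a 3.2-fold lower number from compound 1 to compound 2 (0.50 log units; beyond the scatter) seen on the core of compound 1. The author therefore estimates that compound 4 will give about 3.3 mg/kg in this assay, with a likely range from 1.5 mg/kg to 8 mg/kg.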

Compound 4, dose for half-maximal effect: 8.6 mg/kg
Compound 4: the middle estimate sits 2.6-fold (0.42 log units) below what was measured; measured number outside the range, above it.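

In this assay, bromo in place of chloro on an aromatic carbon gave a 1.1-fold lower number from compound 3 to compound 4 (0.03 log units; within the scatter), so compound 3 and compound 4 cannot be told apart, whereas the same change on the core of compound 1 gave a 3.2-fold lower number from compound 1 to compound 2 (0.50 log units; beyond the scatter). The change therefore did not carry over from one core to the other with the same size, and the two steps differ: the same change on two cores in this assay, a 3.2-fold lower number (0.50 log units; beyond the scatter) from compound 1 to compound 2 and a 1.1-fold lower number (0.03 log units; within the scatter) from compound 3 to compound 4, 3.0-fold (0.47 log units) apart, beyond the scatter of two such steps This shows that, for these two cores, the step from chloro to bromo cannot simply be transferred, but it does not show which feature of the cores sets the two steps apart, since the difference between the cores is not broken down here.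

The compounds shown leave open how other groups in the same place, such as fluoro, trifluoromethyl or a nitrile, would behave on either core. Also open, from the compounds shown here alone, is whether a core with only part of the difference between these two would follow the larger step or the smaller one.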